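The compounds below may be only part of what the source reports. "The series", "measured", "known", "first", "only" and "open" are said of these compounds alone.

In a functional assay on MCF7 cells (Homo sapiens) for inhibition, read by MTT assay, with a stated time of 48 h, tested at 10 uM (a higher number here means more inhibition of growth at the concentration tested, a lower number less inhibition of growth), three compounds sharing one core have been measured. Compound 1 `Cc1oc2c([C@H]3CCN(C)C[C@H]3O)c(O)cc(O)c2c(=O)c1C(O)c1ccc(Cl)cc1` gives 6%, compound 2 `Cc1oc2c([C@H]3CCN(C)C[C@H]3O)c(O)cc(O)c2c(=O)c1C(O)c1cccc(Cl)c1` gives 5% and compound 3 `Cc1oc2c([C@H]3CCN(C)C[C@H]3O)c(O)cc(O)c2c(=O)c1C(O)c1ccc(F)c(Br)c1` gives 14%. Compound 3 stands within the scatter of the other two, as the steps show: a number 8 percentage points higher from compound 1 to compound 3 (within the scatter) and a number 9 percentage points higher from compound 2 to compound 3 (within the scatter). The remaining step, a number 1 percentage points lower from compound 1 to compound 2 (within the scatter), is also within the scatter.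

Compound 4 `Cc1oc2c([C@H]3CCN(C)C[C@H]3O)c(O)cc(O)c2c(=O)c1C(O)c1csc([N+](=O)[O-])c1` keeps the core and differs from compound 3 at a single place: 5-nitrothiophen-3-yl in place of 3-bromo-4-fluorophenyl on a saturated chain carbon bound to an aromatic carbon and an oxygen on a saturated carbon. In words, it has 5-nitrothiophen-3-yl in place of 3-bromo-4-fluorophenyl on a saturated chain carbon bound to an aromatic carbon and an oxygen on a saturated carbon.

All three measured steps were made at this same place, and none left the scatter. However, they exchange only substituted phenyl groups, and no measured compound carries a five-membered ring there. The step expected is therefore small, a number 6 percentage points lower from compound 3 to compound 4 (within the scatter), and it is not expected to go beyond the scatter. For compound 4 the estimated value is 8%, with an expected range from 0% to 22%.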

Compound 4, percent growth inhibition at one concentration: 20%
The estimate for compound 4 lay 12 percentage points below the measured number; the measured number falls inside the stated range.
By their numbers in this assay, from the lowest: compounds 2, 1, 3 and 4 (each within the scatter of the next, the first and the last beyond it).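

In this assay, only the 5-nitrothiophen-3-yl group, on a saturated chain carbon bound to an aromatic carbon and an oxygen on a saturated carbon, separates compounds beyond the scatter, against 3-chlorophenyl (a number 15 percentage points higher from compound 2 to compound 4 (beyond the scatter)) and against 4-chlorophenyl (a number 14 percentage points higher from compound 1 to compound 4 (beyond the scatter)). Against 3-bromo-4-fluorophenyl the same kind of exchange stays within the scatter (a number 6 percentage points higher from compound 3 to compound 4 (within the scatter)), so this position shows a measurable response to the change of ring only against the two chlorophenyl compounds. Nothing available gives a reason for this result.

As far as these compounds go, whether the higher number goes with the nitro group or with the thiophene ring stays open, and a plain thiophen-3-yl group and a nitrophenyl group would separate the two. From the compounds shown here alone, how an amine or a carboxylic acid on that ring would read in this assay also stays open.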